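The source may hold more compounds than are shown below. What is called first, only, known or untested is meant among the compounds shown, and "the series" means these compounds.

In a functional assay on MDA-MB-453 cells (Homo sapiens) for cytotoxicity, read by MTT assay, with a stated time of 48 h (a higher number here means a weaker inhibitor, a lower number a stronger inhibitor), compound 3 (`Cc1ccc(-c2nnc(COc3ccc(-c4nnco4)cc3)o2)cc1`) reads > 50000 nM, which is a limit of the assay and not a number. Compound 2 (`c1ccc(-c2nnc(COc3ccc(-c4nnco4)cc3)o2)cc1`) reads > 50000 nM, which is also a limit. This pair accounts for (the limit of > 50000 nM in this assay, at which 2 of the 3 values shown sit). For the measured compounds named here, the only measured step between compounds differing in one place, methyl in place of hydrogen on an aromatic carbon, is a step that the two limits leave unreadable from compound 2 to compound 3, so it offers no size to carry forward.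

Compound 4 (`Clc1ccc(-c2nnc(COc3ccc(-c4nnco4)cc3)o2)cc1`) differs from compound 3 by chloro in place of methyl on an aromatic carbon, para to a large group, turning 4-methylphenyl into 4-chlorophenyl. The nearest numerical guide is compound 1 (`COc1cc(C#N)ccc1OCc1nnc(-c2ccc(Cl)cc2)o1`), which carries the 4-chlorophenyl group on a different remainder and gives 33900 nM. That value points to weak activity for compound 4, with a further reading at the limit quite possible. The expected change is an at least 1.1-fold lower number from compound 3 to compound 4 (0.04 log units; that floor lies within the scatter), and its size remains uncertain. For compound 4 the estimated value in this assay is 45000 nM, with an expected range from 18000 nM to 90000 nM.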

Compound 4, half-maximal inhibitory concentration: > 50000 nM
Compound 4: no number, only a limit; the forecaster's own chance of this, stated with the estimate: 50%; at least 1.1-fold (0.04 log units) between middle value and limit.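

In this assay compound 4 gives > 50000 nM, which is a limit of the assay and not a number. The steps to compound 4 from compound 2 and compound 3 therefore cannot be read: the limit of > 50000 nM in this assay, at which 3 of the 4 values shown sit.

The compounds shown leave open whether hydrogen, methyl or chloro at this place changes the reading on the shared core at all.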